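Low Toxicity Across Three Side Groups, and a Fourth

The source may hold more compounds than are shown below. What is called first, only, known or untested is meant among the compounds shown, and "the series" means these compounds.

Measured in an ADME assay on MDBK cells (Bos taurus) for cytotoxicity; on this read-out higher numbers stand for lower toxicity in this test and lower numbers for higher toxicity in this test:
- compound 1 `Brc1ccccc1Cn1ccc2nc(-c3ccccc3)nc-2c1`: > 100000 nM (a limit)
- compound 2 `Brc1ccc(Cn2ccc3nc(-c4ccccc4)nc-3c2)cc1`: 83000 nM
- compound 3 `c1ccc(CCCn2ccc3nc(-c4ccccc4)nc-3c2)cc1`: > 100000 nM (a limit)

Compound 3 sits at the limit of > 100000 nM in this assay, at which 2 of the 3 values shown sit. This is a limit, not a number.

The next compound, compound 4 `CCC(CC)Cn1ccc2nc(-c3ccccc3)nc-2c1`, carries pentan-3-yl in place of phenethyl on a saturated chain carbon bound to an aromatic nitrogen.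

The three measured steps all change the group at this same place. They show an at least 1.2-fold lower number from compound 1 to compound 2 (0.08 log units; that floor lies within the scatter), then an at least 1.2-fold higher number from compound 2 to compound 3 (0.08 log units; that floor lies within the scatter), and finally a step that the two limits leave unreadable from compound 1 to compound 3. None of them shows a change beyond the scatter in this assay, so none beyond the scatter is expected here. The expectation is loose, since the entering group has no ring and the groups in compounds 1, 2 and 3 all do.

The expected change is an at least 1.0-fold lower number from compound 3 to compound 4 (0.02 log units; that floor lies within the scatter). Compound 4 is estimated at 95000 nM, with an expected range from 50000 nM to 180000 nM.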

Compound 4, half-maximal cytotoxic concentration: > 100000 nM
Compound 4 ended at the assay's limit; the forecaster's own chance of this, stated with the estimate: 60%; middle value at least 1.0-fold (0.02 log units) from the limit.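

In this assay compound 4, whose pentan-3-yl group has no ring, gives > 100000 nM, a limit and not a number, so a ring in the group at this place is not needed to reach that limit. Among these compounds, the one readable step is an at least 1.2-fold higher number from compound 2 to compound 4 (0.08 log units; that floor lies within the scatter), and the steps from compound 1 and from compound 3 to compound 4 cannot be read, with limits at both ends. Ring-bearing and ring-free groups now give similar results at this place, but the read-out has little room left to separate them: the limit of > 100000 nM in this assay, at which 3 of the 4 values shown sit.

From the compounds shown here alone, how far past that limit compounds 1, 3 and 4 lie remains unknown, so they cannot be ranked against one another. Going by these compounds, whether an amine or a carboxylic acid on this chain would bring the number down also remains open.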